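Iodo to bromo swap across two cores

The compounds below may be only part of what the source reports. "The series", "measured", "known", "first", "only" and "open" are said of these compounds alone.

Compound 1 `O=C(Nc1ccc(Br)cc1F)c1cc(I)ccc1O` and compound 2 `O=C(Nc1ccc(Br)cc1F)c1cc(Br)ccc1O` share one core; compound 3 `O=c1oc2ccc(Cl)cc2c(=O)n1-c1ccc(I)cc1F` and the unmeasured compound 4 `O=c1oc2ccc(Cl)cc2c(=O)n1-c1ccc(Br)cc1F` share another. How the two cores differ is not broken down here. In an ADME assay on RAW264.7 cells (Mus musculus) for cytotoxicity, read by MTT assay, with a stated time of 24 h (a higher number here means that more compound is tolerated, a lower number that less compound is tolerated), compound 1 gives 8400 nM, compound 2 gives 7800 nM, and compound 3 gives 6900 nM; all three values lie within the scatter of one another.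

The change from compound 1 to compound 2 is bromo in place of iodo on an aromatic carbon, which gave a 1.1-fold lower number from compound 1 to compound 2 (0.03 log units; within the scatter). The change from compound 3 to compound 4 is bromo in place of iodo on an aromatic carbon. This is the same kind of change, though the surroundings differ: in the first case the place is meta to a large group and para to a hydroxy group, in the second meta to a fluoro group and para to a large group.

The step of a 1.1-fold lower number from compound 3 to compound 4 (0.03 log units; within the scatter) is expected to be small, since the earlier step of a 1.1-fold lower number from compound 1 to compound 2 (0.03 log units; within the scatter) stayed within the scatter. Compound 4 is therefore estimated at 6500 nM, with a range from 3500 nM to 12000 nM.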

Compound 4, half-maximal cytotoxic concentration: 8100 nM
The estimate for compound 4 lay 1.2-fold (0.10 log units) below the measured number, within the range that was stated.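

In this assay, bromo in place of iodo on an aromatic carbon gives a 1.2-fold higher number from compound 3 to compound 4 (0.07 log units; within the scatter), so on the core of compound 3 this swap again produces only a small step, as it does on the core of compound 1. The two steps agree within the scatter, and the swap carries over between these two cores without any visible difference: the same change on two cores in this assay, a 1.1-fold lower number (0.03 log units; within the scatter) from compound 1 to compound 2 and a 1.2-fold higher number (0.07 log units; within the scatter) from compound 3 to compound 4, 1.3-fold (0.10 log units) apart, within the scatter of two such steps. This holds for two pairs in one assay only; since both steps lie within the scatter, neither gives a direction for the swap, and neither shows how it would behave on a further core or in another read-out.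

The compounds shown carry only iodo and bromo at this place, so it remains open whether a chloro group, a methyl group, an amine or a carboxylic acid there would move the number beyond the scatter. Also open, as far as these compounds go, is whether a change elsewhere, such as an amine in place of the hydroxy group of compound 1, would do so.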